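The compounds below may be only part of what the source reports. "The series", "measured", "known", "first", "only" and "open" are said of these compounds alone.

Measured compounds:

Compound 1 `COC(=O)c1c(C)[n+]([O-])c2cc(Cl)c(Cl)cc2[n+]1[O-]` gives 1.68 ug/mL in an ADME assay on Vero cells (Chlorocebus sabaeus) for cytotoxicity; on this read-out higher numbers stand for weaker inhibition and lower numbers for stronger inhibition.

Compound 2 `COC(=O)c1c(C)[n+]([O-])c2cc(F)c(F)cc2[n+]1[O-]` gives 1.48 ug/mL in this assay.

Compound 3 `CCc1c(C(=O)OC)[n+]([O-])c2cc(Cl)c(Cl)cc2[n+]1[O-]` gives 4 ug/mL in this assay.

Compound 1 and compound 3 share a core and differ in one place: methyl in place of hydrogen on a saturated chain carbon bound to an aromatic carbon. This change gave a 2.4-fold higher number from compound 1 to compound 3 (0.38 log units; beyond the scatter), a move toward weaker inhibition of the cells. Compound 2 carries a different core; the difference between the two cores is not broken down here. In this assay the values of compound 1 and compound 2 lie within the scatter of each other, so nothing can be said about their order.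

Compound 4 `CCc1c(C(=O)OC)[n+]([O-])c2cc(F)c(F)cc2[n+]1[O-]` has not yet been measured. It stands to compound 2 as compound 3 stands to compound 1: methyl in place of hydrogen on a saturated chain carbon bound to an aromatic carbon. The place of the change is described in the same words for both pairs, so it is the same change, made this time on the core of compound 2.

One prior example of this change is known, and it moved the number upward by a modest amount. A step of the same kind is expected from compound 2 to compound 4, namely a 2.4-fold higher number from compound 2 to compound 4 (0.37 log units; beyond the scatter), and this expectation rests on the step of a 2.4-fold higher number from compound 1 to compound 3 (0.38 log units; beyond the scatter) seen on the core of compound 1. Going by the values given here, since only one earlier example exists, the uncertainty is broader than that single step suggests. Compound 4 is therefore estimated to give 3.5 ug/mL in this assay, with the likely range running from 1.8 ug/mL to 7 ug/mL.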

Compound 4, half-maximal inhibitory concentration: 1.2 ug/mL
Beside the measured number, compound 4's estimate is 2.9-fold (0.46 log units) above it; measured number below the stated range.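

In this assay, going by these compounds alone, the change from methyl to ethyl on the core of compound 2 gave a 1.2-fold lower number from compound 2 to compound 4 (0.09 log units; within the scatter), so on this core the added carbon produced no step that can be told apart from the scatter of repeated measurements. Within the data shown here, the same change therefore did not carry over from one core to the other in this assay, and the mismatch between the two steps is larger than such scatter would allow: the same change on two cores in this assay, a 2.4-fold higher number (0.38 log units; beyond the scatter) from compound 1 to compound 3 and a 1.2-fold lower number (0.09 log units; within the scatter) from compound 2 to compound 4, 2.9-fold (0.47 log units) apart, beyond the scatter of two such steps This shows that, in this series, a step seen on one core is an unsafe guide to the same change on another, but with only two pairs it does not show why the cores differ, which of the two steps is more typical, or how the change would behave on any third core.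

The compounds shown stop at methyl and ethyl at this place, so it remains open whether a longer chain, such as propyl or butyl, would raise the number on the core of compound 1 and leave it flat on the core of compound 2. Also open, as far as these compounds go, is how either core would respond to a chain ending in an amine or a carboxylic acid at the same place.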